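Urea series on L1210 cells: the step to compound 4

This account rests on a few compounds, and the source may have more. Where it says the series, first, only, none or still open, it means among the compounds named here.

Measured in a functional assay on L1210 cells (Mus musculus), read by MTT assay, with a stated time of 72 h; on this read-out lower numbers stand for stronger inhibition and higher numbers for weaker inhibition:
compound 1 `COc1cc(NC(C)CCCNC(=O)NC(c2ccccc2)c2ccccc2)c2ncccc2c1`: > 500000 nM, a limit of this assay and not a number
compound 2 `COc1cc(NC(C)CCCNC(=O)NC2CCCCC2)c2ncccc2c1`: 23000 nM
compound 3 `COc1cc(NC(C)CCCNC(=O)N(C2CCCCC2)C2CCCCC2)c2ncccc2c1`: 15000 nM

Compound 2 holds the higher of the two numbers; its nearest neighbour is compound 3, and the step of a 1.5-fold lower number from compound 2 to compound 3 (0.19 log units; within the scatter) lies within the scatter. Compound 1 sits at the limit of > 500000 nM in this assay, at which 1 of the 3 values shown sits, which says nothing about its number.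

Compound 4 `COc1cc(NC(C)CCCNC(=O)n2nnc3ccccc32)c2ncccc2c1` differs from compound 2 by a group of 9 heavy atoms (6 carbon, 3 nitrogen; one five-membered aromatic ring with 3 hetero atoms, one six-membered aromatic ring of carbon only) in place of a group of 7 heavy atoms (6 carbon, 1 nitrogen; one six-membered non-aromatic ring of carbon only), on a carbonyl carbon. Among the measured compounds shown here, the only measured step in this assay touches the same urea end and was within the scatter; no measured step covers a heteroaromatic group on the carbonyl carbon. The step from compound 2 to compound 4 is therefore expected to stay within the scatter, a 1.2-fold lower number from compound 2 to compound 4 (0.06 log units; within the scatter). Compound 4 is estimated at 20000 nM, with a range of 5000 nM to 80000 nM.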

Compound 4, half-maximal inhibitory concentration: 125000 nM
Compound 4: middle estimate off by 6.3-fold (0.80 log units), on the low side, outside the stated range (above it).
By their numbers in this assay, from the lowest: compounds 3 and 2 (each within the scatter of the next); then compound 4. At a limit, above all of these: compound 1.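

The carbonyl carbon of this urea end is sensitive to what it carries: in this assay, replacing cyclohexylamino with the group of two aromatic rings gives a 5.4-fold higher number from compound 2 to compound 4 (0.74 log units; beyond the scatter), whereas the earlier change on the amide-type nitrogen gave a 1.5-fold lower number from compound 2 to compound 3 (0.19 log units; within the scatter). This change swaps a non-aromatic ring for aromatic rings and removes the hydrogen-bond donor of cyclohexylamino, and the two are not separated here. Nothing measured here accounts for the step.

Still open, as far as these compounds go, is whether phenylamino or dimethylamino on the carbonyl carbon would read close to compound 2 or to compound 4.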